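Carboxy in place of cyano, starting from a limit

A few compounds are considered here, and "the series" means these few. Any claim that something is new, unique, unknown or untested is made for them only; others in the source may bear on it.

In a functional assay on KB cells (Homo sapiens) for antiproliferative activity, read by sulforhodamine B assay, with a stated time of 48 h (a higher number here means a weaker inhibitor of growth, a lower number a stronger inhibitor of growth), the measured compounds give
Compound 1 `COc1ccc(Nc2nc(NC3CCCC3)c3ccccc3n2)cc1` gives 11100 nM
Compound 2 `COc1ccc(Nc2nc(NC3CC3)c3ccccc3n2)cc1` gives 13300 nM
Compound 3 `N#Cc1ccc(Nc2nc(NC3CCCC3)c3ccccc3n2)cc1` gives > 31300 nM (a limit, not a number)

Compound 3 has no exact number and stands only at a limit (the limit of > 31300 nM in this assay, at which 1 of the 3 values shown sits). Compound 4 `O=C(O)c1ccc(Nc2nc(NC3CCCC3)c3ccccc3n2)cc1` carries carboxy in place of cyano on an aromatic carbon, para to a large group (carboxy in place of cyano on an aromatic carbon). The same place changed once before, where cyano in place of methoxy gave an at least 2.8-fold higher number from compound 1 to compound 3 (0.45 log units; beyond the scatter) and so cost activity. The other step, a 1.2-fold higher number from compound 1 to compound 2 (0.08 log units; within the scatter) with its cyclopropyl for cyclopentyl, lies elsewhere and bears little on this change. Among the measured compounds shown here, no measured compound carries carboxy, so no step beyond the scatter is expected in this assay here. The estimated step is an at least 1.0-fold lower number from compound 3 to compound 4 (0.01 log units; that floor lies within the scatter) and no more. Compound 4 is estimated at 30000 nM (expected range 11000 nM to 60000 nM) and may again return only a limit.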

Compound 4, concentration for 50% growth inhibition: 25200 nM
Compound 4: middle estimate off by 1.2-fold (0.08 log units), on the high side, and the stated range covers the measured number.
By their numbers in this assay, from the lowest: compounds 1, 2 and 4 (each within the scatter of the next, the first and the last beyond it). At a limit, above all of these: compound 3.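

In this assay, a second replacement of methoxy at this position also costs activity, with carboxy giving a 2.3-fold higher number from compound 1 to compound 4 (0.36 log units; beyond the scatter), so both groups tried here in place of methoxy, cyano and carboxy, do worse than methoxy. Between those two groups, the change gives an at least 1.2-fold lower number from compound 3 to compound 4 (0.09 log units; that floor lies within the scatter), so no gain beyond the scatter can be claimed. Compound 3 stands only at a limit, which leaves the true size of that step unknown: the limit of > 31300 nM in this assay, at which 1 of the 4 values shown sits.

Going by these compounds, whether any group here can beat methoxy stays open. An amine or a longer ether chain at this position would test that.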